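Anilinothiazole hydrazide series: bromo to methoxy step

This account rests on a few compounds, and the source may have more. Where it says the series, first, only, none or still open, it means among the compounds named here.

Measured so far in a functional assay on C6 cells (Rattus norvegicus) for cytotoxicity, read by MTT assay, with a stated time of 24 h, tested at 50 ug/mL; a higher number here means a weaker effect of the compound at the concentration tested, a lower number a stronger effect:
compound 1, `O=C(CSc1nnnn1-c1ccccc1)N/N=c1/scc(-c2ccc(Br)cc2)n1-c1ccccc1`: 32%
compound 2, `Cc1ccc(-c2cs/c(=N/NC(=O)CSc3nncn3C)n2-c2ccccc2)cc1`: 53.8%
compound 3, `O=C(CSc1ncccn1)N/N=c1/scc(-c2ccc(Br)cc2)n1-c1ccccc1`: 69%

Compound 3 stands highest of the three numbers in this assay; compound 2 lies nearest, and compound 1 furthest, both gaps beyond the scatter. Within the data shown here, the one step measured, a number 37 percentage points higher from compound 1 to compound 3 (beyond the scatter), concerns the group on the sulfur and not the aryl ring, so it does not bear on the change now considered.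

Compound 4, `COc1ccc(-c2cs/c(=N/NC(=O)CSc3ncccn3)n2-c2ccccc2)cc1`, differs from compound 3 only on the aryl ring: methoxy in place of bromo on an aromatic carbon. Among the measured compounds shown here, no measured pair changes the substituent on that ring alone; compound 2 carries a methyl there but also a different group on the sulfur, so its value cannot be read as a step for the ring alone. With nothing to lean on, no step beyond the scatter is expected for a number 3 percentage points higher from compound 3 to compound 4 (within the scatter). Compound 4 is therefore estimated at 72% in this assay, within 55% to 90%.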

Compound 4, a percentage reported as activity, at one concentration (the size of the read-out at that concentration, not a potency): 66.5%
The estimate for compound 4 lay 5.5 percentage points above the measured number, within the range that was stated.
By their numbers in this assay, from the lowest: compound 1; then compound 2; then compounds 4 and 3 (each within the scatter of the next).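

Among these compounds, with pyrimidin-2-yl held on the sulfur, the change from 4-bromophenyl to 4-methoxyphenyl gives the first reading of this ring position alone in this assay, with a number 2.5 percentage points lower from compound 3 to compound 4 (within the scatter). Among the compounds shown here, in this pair, methoxy in place of bromo on an aromatic carbon therefore leaves the read-out within the scatter, while the only earlier step, made on the sulfur and not on the ring, is large, with a number 37 percentage points higher from compound 1 to compound 3 (beyond the scatter). No measurement at hand accounts for either step.

For the compounds shown here, the ring change has been read with only one group on the sulfur, so it remains open whether it would also stay within the scatter with the 1-phenyl-1H-tetrazol-5-yl group of compound 1 at 32%. Also open, as far as these compounds go, is how an amine or a carboxylic acid would read in place of bromo at this position.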